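The source may report more compounds than this note shows. Statements on the series, on what has been measured and on what is new or still open speak of the compounds shown alone.

The measured compounds:
Compound 1, `CSc1nnc(Cc2ccc(Cl)cc2Oc2ccccc2Cl)[nH]1`, gives 170% in a functional assay on the whole organism (strain NMRI) with Mus musculus as the target, with a stated time of 60 min, at a dose of 20 mg/kg by the intraperitoneal route; on this read-out higher numbers stand for a stronger effect at the one dose given and lower numbers for a weaker effect.
Compound 2, `CSc1nnc(Cc2ccc(Cl)cc2Oc2ccccc2F)[nH]1`, gives 136%.
Compound 3, `CCOc1nnc(Cc2ccccc2Oc2ccccc2)[nH]1`, gives 144%.

Compound 1 holds the highest of the three numbers; compound 3 comes nearest to it, and compound 2 lies furthest below, both gaps beyond the scatter. Going by the values given here, the only step between compounds that differ in a single place is a number 34 percentage points lower from compound 1 to compound 2 (beyond the scatter). The account now follows compound 1 to compound 4, `CCOc1nnc(Cc2ccc(Cl)cc2Oc2ccccc2Cl)[nH]1`, which has not been measured. The change is ethoxy in place of methylsulfanyl on an aromatic carbon. Among the compounds with values here, no measured step covers this change: the step from compound 1 to compound 2 concerns a different group on a different ring, and compound 3, the only measured compound bearing ethoxy on the shared core, differs from compound 1 in more than one place, so its value shows only that an ethoxy compound can reach a high number. In this assay compound 4 is therefore expected to give 150%, within 110% to 190%, an expected step of a number 20 percentage points lower from compound 1 to compound 4 (beyond the scatter).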

Compound 4, a percentage reported as activity, at one dose (the size of the read-out at that dose, not a potency): 135%
Compound 4: middle estimate off by 15 percentage points, on the high side; measured number inside the range.
By their numbers in this assay, from the lowest: compounds 4, 2 and 3 (each within the scatter of the next); then compound 1.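

On the aromatic carbon of the five-membered ring, between two ring nitrogen atoms, this assay now has a direct reading: ethoxy in place of methylsulfanyl gives a number 35 percentage points lower from compound 1 to compound 4 (beyond the scatter) and this step is large. The earlier step, a number 34 percentage points lower from compound 1 to compound 2 (beyond the scatter), concerned a different group on a different ring, so the read-out is now seen to respond to a change at this position as well. The data offered give no explanation for this step.

Going by these compounds alone, with only this one exchange at the position, it stays open whether the step goes with oxygen replacing sulfur or with the longer chain, and a methoxy or ethylsulfanyl group there would separate the two. Also open, as far as these compounds go, are how an amine would fare at this place and whether the step would hold with the fluoro group of compound 2.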